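Amino in Place of Bromo on the Shared Core

A few compounds are considered here, and "the series" means these few. Any claim that something is new, unique, unknown or untested is made for them only; others in the source may bear on it.

Of the compounds shown here, three have been measured in an assay on isolated protein for inhibition of tyrosine-protein kinase receptor UFO (Homo sapiens), with a stated time of 1.5 h; on this read-out lower numbers stand for stronger inhibition and higher numbers for weaker inhibition. Compound 1 `Cn1cc(-c2n[nH]c3ccc(Br)cc23)cn1` gives 1540 nM, the second highest of the three numbers. Compound 2 `N#Cc1ccc(-n2cc(-c3n[nH]c4cc(Cl)c(N[C@@H]5CCNC5)cc34)cn2)cc1` gives 700 nM, a lower number that lies beyond the usual scatter, while compound 3 `O=C1CC(c2ccccc2)=NN1` gives 13000 nM, a higher number that also lies beyond the scatter. Compound 4 `Cn1cc(-c2n[nH]c3ccc(N)cc23)cn1` has not yet been measured; it keeps the core of compound 1 and differs in one place: amino in place of bromo on an aromatic carbon. For the measured compounds named here, no pair of measured compounds shows what such a swap does here, so the direction cannot be read from the data. A modest move toward a weaker result is expected, with the step estimated at a 1.6-fold higher number from compound 1 to compound 4 (0.21 log units; within the scatter). Compound 4 is thus expected to give about 2500 nM, within a range from 800 nM to 8000 nM.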

Compound 4, half-maximal inhibitory concentration: 8910 nM
Beside the measured number, compound 4's estimate is 3.6-fold (0.55 log units) below it; the measured number lies above the stated range.
By their numbers in this assay, from the lowest: compound 2; then compound 1; then compounds 4 and 3 (each within the scatter of the next).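

For the compounds shown here, the swap gives the first direct reading of this position: in this assay, amino in place of bromo on the aromatic carbon moves the result toward weaker inhibition, with a 5.8-fold higher number from compound 1 to compound 4 (0.76 log units; beyond the scatter) in a change of a single heavy atom. This carbon of the shared core is therefore not indifferent to what it carries, and bromo serves better than amino here. Nothing available explains why the number rises. Still open, on these data alone, is whether fluoro, methyl or methoxy on this carbon would match bromo, and whether the same swap would act alike on another core.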